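This account rests on a few compounds, and the source may have more. Where it says the series, first, only, none or still open, it means among the compounds named here.

Compound 1 `COc1cccc(NC(=O)c2ccc3cccc(O)c3n2)c1` gives a limit of > 30000 nM in an ADME assay on THP-1 cells (Homo sapiens) for cytotoxicity, read by WST assay, with a stated time of 24 h; a lower number here means a stronger inhibitor, a higher number a weaker inhibitor. Compound 2 `Cc1ccccc1NC(=O)c1ccc2cccc(O)c2n1` likewise reaches only a limit of > 30000 nM in this assay. Compound 3 `Cc1ccc(NC(=O)c2ccc3cccc(O)c3n2)cc1` also shows a limit of > 30000 nM in this assay.

Compound 3 thus stands at the limit of > 30000 nM in this assay, at which 3 of the 3 values shown sit, and no number places it relative to the others. For the measured compounds named here, the one step among measured compounds, a step that the two limits leave unreadable from compound 2 to compound 3, stays unreadable for the same reason. Compound 4 `O=C(Nc1ccc(F)cc1)c1ccc2cccc(O)c2n1` carries fluoro in place of methyl on an aromatic carbon. Going by the values given here, no measured step bears readably on this change, so no step beyond the scatter is expected in this assay, and the estimate is a step that the limit leaves unreadable from compound 3 to compound 4. Compound 4 is therefore expected to come out near 50000 nM, between 20000 nM and 150000 nM, most likely again as a limit.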

Compound 4, half-maximal inhibitory concentration: > 30000 nM
Compound 4 was reported as a limit; the forecaster's own chance of this, stated with the estimate: 85%; the middle value is on the limit's open side.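

For the compounds shown here, no step to compound 4, from compound 2 or from compound 3, can be read, because each value is only a limit: the limit of > 30000 nM in this assay, at which 4 of the 4 values shown sit. In this assay the compounds shown leave open where any true value lies, and whether changing the group on the amide nitrogen shifts it.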